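Replacing the bromophenyl thioether arm with an isopentyl chain

The compounds below may be only part of what the source reports. "The series", "measured", "known", "first", "only" and "open" are said of these compounds alone.

Among the measured compounds shown here, compound 3 `Cn1c(=O)c2c(nc(SCc3ccc(Br)cc3)n2C)n(C)c1=O` gives 2620 nM in an assay on isolated protein for inhibition of Amine oxidase [flavin-containing] A (Homo sapiens), read by fluorescence (a higher number here means a weaker inhibitor, a lower number a stronger inhibitor), the lowest of the three numbers known. Compound 2 `Cn1c(=O)c2c(nc(SCCOc3ccccc3)n2C)n(C)c1=O` gives 15500 nM and compound 1 `Cn1c(=O)c2c(nc(Sc3ccccc3)n2C)n(C)c1=O` gives 56400 nM in this assay. Compound 4 `CC(C)CCSc1nc2c(c(=O)n(C)c(=O)n2C)n1C` differs from compound 3 by isobutyl in place of 4-bromophenyl on a saturated chain carbon bound to a sulfur. For the measured compounds named here, the one measured step at this carbon, a 5.9-fold lower number from compound 2 to compound 3 (0.77 log units; beyond the scatter), shows that the 4-bromophenyl group is the arm under which the number fell; the present change removes it and puts in a group with no ring, so a partial return toward the number of compound 2 is expected, although no isobutyl arm has been tested here. Compound 4 is estimated at 9000 nM, with a range of 2500 nM to 40000 nM, an expected step of a 3.4-fold higher number from compound 3 to compound 4 (0.54 log units; beyond the scatter).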

Compound 4, half-maximal inhibitory concentration: 15200 nM
For compound 4 the middle estimate is 1.7-fold (0.23 log units) below the measured one, and the stated range covers the measured number.
By their numbers in this assay, from the lowest: compound 3; then compounds 4 and 2 (each within the scatter of the next); then compound 1.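

In this assay the isobutyl arm gives up what the 4-bromophenyl arm had gained (a 5.8-fold higher number from compound 3 to compound 4 (0.76 log units; beyond the scatter)), so compound 3 stands apart from a chain with no ring at this carbon. No ring is needed to match the phenoxy-ended arm (a 1.0-fold lower number from compound 2 to compound 4 (0.01 log units; within the scatter)), and the isopentyl chain on the sulfur still gives a lower number than phenyl there (a 3.7-fold lower number from compound 1 to compound 4 (0.57 log units; beyond the scatter)). Nothing available explains these differences. Going by these compounds, it remains open whether the bromine or the ring carries the step, which a plain benzyl or 4-chlorobenzyl arm would separate, and how a longer chain would fare.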